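The source may hold more compounds than are shown below. What is called first, only, known or untested is meant among the compounds shown, and "the series" means these compounds.

The measured compounds:

- compound 1, `Cc1ccc(C(=O)Nc2cc(-n3ccnc3)cc(C(F)(F)F)c2)cc1Nc1nc(-c2cccnc2)cs1`, 28 nM
- compound 2, `Cc1ncn(-c2cc(NC(=O)c3ccc(C)c(Nc4nc(-c5cccnc5)cs4)c3)cc(C(F)(F)F)c2)n1`, 26 nM
- compound 3, `Cc1ccc(C(=O)Nc2cc(-c3cnn(C)c3)cc(C(F)(F)F)c2)cc1Nc1nc(-c2cccnc2)cs1`, 27 nM

In a functional assay on K562 cells (Homo sapiens) for antiproliferative activity (on this read-out higher numbers stand for weaker inhibition and lower numbers for stronger inhibition), compound 2 gives the lowest of the three numbers, yet its neighbours stand within the scatter of it: the step from compound 1 to compound 2 is a 1.1-fold lower number from compound 1 to compound 2 (0.03 log units; within the scatter), and that from compound 2 to compound 3 is a 1.0-fold higher number from compound 2 to compound 3 (0.02 log units; within the scatter). The step from compound 1 to compound 3, a 1.0-fold lower number from compound 1 to compound 3 (0.02 log units; within the scatter), likewise stays within the scatter. All three measured steps exchange one five-membered aromatic ring for another at the same aromatic carbon.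

Compound 4, `Cc1ccc(C(=O)Nc2cccc(C(F)(F)F)c2)cc1Nc1nc(-c2cccnc2)cs1`, is unmeasured. It differs from compound 2 in one place: hydrogen in place of 3-methyl-1H-1,2,4-triazol-1-yl on an aromatic carbon. For the measured compounds named here, none of the measured steps removes this ring altogether, so they bear on the change only indirectly: they show that exchanging one such ring for another leaves the number in this assay unchanged beyond the scatter. Removing the ring is a larger change, and a shift toward a higher number is expected for compound 4, though with wide uncertainty: the estimated step is a 2.7-fold higher number from compound 2 to compound 4 (0.43 log units; beyond the scatter). For compound 4 the estimate in this assay is 70 nM, ranging from 20 nM to 300 nM.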

Compound 4, half-maximal inhibitory concentration: 3010 nM
Compound 4: the middle estimate sits 43-fold (1.63 log units) below what was measured; the whole stated range lies below it.
By their numbers in this assay, from the lowest: compounds 2, 3 and 1 (each within the scatter of the next); then compound 4.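

Hydrogen in place of the ring gives a 120-fold higher number from compound 2 to compound 4 (2.06 log units; beyond the scatter) in this assay and the same exchange gives a 110-fold higher number from compound 3 to compound 4 (2.05 log units; beyond the scatter) and a 110-fold higher number from compound 1 to compound 4 (2.03 log units; beyond the scatter) at this one carbon. The earlier steps showed only that these three rings can stand in for one another within the scatter; now all three steps to hydrogen are large, so among the compounds shown, having one of these rings at this place counts for far more than which one it is. Nothing shown accounts for the size of this loss.

On these data alone, whether a group smaller than a ring, such as a methyl group or an amine, would keep the low number remains open. So does whether a saturated ring such as morpholine would serve in place of these aromatic ones.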